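This account rests on a few compounds, and the source may have more. Where it says the series, first, only, none or still open, it means among the compounds named here.

In a functional assay on HepG2 cells (Homo sapiens) for antiproliferative activity, read by MTT assay, with a stated time of 24 h (on this read-out lower numbers stand for stronger inhibition and higher numbers for weaker inhibition), compound 1 `Cc1ccc(-c2nn(-c3ccccc3)cc2-c2nc3ccccc3[nH]2)cc1` gives 6260 nM. Compound 2 `Cc1ccc(-c2nn(-c3ccccc3)cc2-c2nc3ccccc3n2S(=O)(=O)c2ccccc2)cc1` gives 960 nM, and compound 3 `Cc1ccc(-c2nn(-c3ccccc3)cc2-c2nc3ccccc3n2S(=O)(=O)c2ccc(C)cc2)cc1` gives 520 nM. Compound 3 thus stands at the low end of the three numbers, though not clearly apart from its nearest neighbour: a 1.8-fold lower number from compound 2 to compound 3 (0.27 log units; within the scatter). Adding the sulfonyl group accounts for the larger steps: a 6.5-fold lower number from compound 1 to compound 2 (0.81 log units; beyond the scatter) and a 12-fold lower number from compound 1 to compound 3 (1.08 log units; beyond the scatter). Compound 4 `Cc1ccc(-c2nn(-c3ccccc3)cc2-c2nc3ccccc3n2S(=O)(=O)c2cc(C)ccc2C)cc1` carries 2,5-dimethylphenyl in place of 4-methylphenyl on a sulfonyl sulfur, with 2,5-dimethylphenyl in place of 4-methylphenyl on a sulfonyl sulfur. Going by the values given here, the closest precedent is the methyl step, a 1.8-fold lower number from compound 2 to compound 3 (0.27 log units; within the scatter), so no step beyond the scatter is expected in this assay. The estimated step is a 1.1-fold lower number from compound 3 to compound 4 (0.03 log units; within the scatter). The expected value for compound 4 is 480 nM, with an estimated range of 200 nM to 1150 nM.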

Compound 4, half-maximal inhibitory concentration: 460 nM
Estimate against measurement, compound 4: 1.0-fold (0.02 log units) above, and the stated range covers the measured number.
By their numbers in this assay, from the lowest: compounds 4, 3 and 2 (each within the scatter of the next, the first and the last beyond it); then compound 1.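

In this assay, 2,5-dimethylphenyl in place of 4-methylphenyl on the sulfonyl sulfur stays within the scatter (a 1.1-fold lower number from compound 3 to compound 4 (0.05 log units; within the scatter)), so a second methyl on this ring is tolerated. Going by these compounds alone, it is also the first change on this ring to pass the scatter against plain phenyl (a 2.1-fold lower number from compound 2 to compound 4 (0.32 log units; beyond the scatter)), if only just, while the large step from the unsubstituted nitrogen persists (a 14-fold lower number from compound 1 to compound 4 (1.13 log units; beyond the scatter)). No available evidence bears on why these steps arise. Still open, from the compounds shown here alone, is whether an amine or a carboxylic acid on this ring would keep these numbers. Going by these compounds, a longer alkyl chain on the sulfur in place of the ring is equally open.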